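The source may hold more compounds than are shown below. What is called first, only, known or untested is meant among the compounds shown, and "the series" means these compounds.

Of the compounds shown here, three sharing one core have been tested in a functional assay on MDA-MB-231 cells (Homo sapiens), read by microscopy and transwell migration, with a stated time of 24 h; a higher number here means a weaker inhibitor, a lower number a stronger inhibitor. Compound 1 `COc1cc(-c2csc(N(C)C(=O)c3ccccc3)n2)cc(OC)c1OC`, with phenyl on the carbonyl carbon, gives 10000 nM. Compound 2 `COc1ccc(C(=O)N(C)c2nc(-c3cc(OC)c(OC)c(OC)c3)cs2)cc1`, with a methoxy in place of hydrogen on an aromatic carbon, gives 312 nM. Compound 3 `COc1cc(-c2csc(N(C)C(=O)c3cccc(OC)c3OC)n2)cc(OC)c1OC`, with 2,3-dimethoxyphenyl on the carbonyl carbon, gives 108 nM, the lowest number of the three and so the strongest inhibitor in this small set.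

Compound 4 `COc1ccccc1C(=O)N(C)c1nc(-c2cc(OC)c(OC)c(OC)c2)cs1` takes one step back from compound 3: hydrogen in place of methoxy on an aromatic carbon, leaving 2-methoxyphenyl. For the measured compounds named here, no tested compound carries that group, so its effect cannot be read directly.

Going by the values given here, three measured steps bear on it. The number falls sharply a 32-fold lower number from compound 1 to compound 2 (1.51 log units; beyond the scatter) and further still a 93-fold lower number from compound 1 to compound 3 (1.97 log units; beyond the scatter), both large steps. Among the compounds with values here, the single methoxy of compound 2 therefore already gives most of the gain, and the step of a 2.9-fold lower number from compound 2 to compound 3 (0.46 log units; beyond the scatter) is only modest. Compound 4 also keeps one methoxy, so it should lie nearer compound 3 than compound 1.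

The expected step is a 3.7-fold higher number from compound 3 to compound 4 (0.57 log units; beyond the scatter), a modest rise in the number, towards a weaker inhibitor. For compound 4 the estimated value is 400 nM, with an expected range from 120 nM to 2500 nM.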

Compound 4, half-maximal inhibitory concentration: > 25000 nM
Compound 4: only a limit was reported; the forecaster's own chance of this, stated with the estimate: 5%; middle value at least 62-fold (1.79 log units) away from the limit.
By their numbers in this assay, from the lowest: compound 3; then compound 2; then compound 1. At a limit, above all of these: compound 4.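

In this assay compound 4 gives > 25000 nM, which is a limit of the assay and not a number. Even so, the steps show that this methoxy is far from a small extra, with an at least 230-fold higher number from compound 3 to compound 4 (2.36 log units; beyond the scatter), and that a single methoxy does not act the same wherever it sits, since 2-methoxyphenyl in place of 4-methoxyphenyl gives an at least 80-fold higher number from compound 2 to compound 4 (1.90 log units; beyond the scatter). Set against plain phenyl, 2-methoxyphenyl brings no gain at all, with an at least 2.5-fold higher number from compound 1 to compound 4 (0.39 log units; beyond the scatter), so what a methoxy adds in this series depends on what else the ring carries, and the same change differs in size on the two cores: the same change on two cores in this assay, a 32-fold lower number (1.51 log units; beyond the scatter) from compound 1 to compound 2 and an at least 230-fold lower number (2.36 log units; beyond the scatter) from compound 4 to compound 3, at least 7.2-fold (0.85 log units) apart, beyond the scatter of two such steps.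

The compounds shown carry only hydrogen or methoxy on this ring, so it stays open whether a fluorine, a hydroxyl or an ethoxy in place of the lost methoxy would keep the low number of compound 3. Also open, on these data alone, is how 3-methoxyphenyl would behave, which would show what this methoxy does without the other one.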